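A few compounds are considered here, and "the series" means these few. Any claim that something is new, unique, unknown or untested is made for them only; others in the source may bear on it.

Working notes on the series. Compound 1 `FC(F)(F)c1ccc(CSc2nc(Nc3cccc(C(F)(F)F)c3)c3ccccc3n2)cc1` gives in a functional assay on MDA-MB-231 cells (Homo sapiens) for cytotoxicity, read by MTT assay, with a stated time of 72 h (a lower number here means a stronger inhibitor, a higher number a weaker inhibitor), a value of 11100 nM. Among the compounds with values here, compound 2 `O=[N+]([O-])c1cccc(Nc2nc(SCc3ccc(C(F)(F)F)cc3)nc3ccccc23)c1` gives in this assay a value of 31500 nM, the highest of the two numbers so far; its nearest neighbour is compound 1, and the step of a 2.8-fold higher number from compound 1 to compound 2 (0.45 log units; beyond the scatter) is the only measured step in the set.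

Compound 3 `FC(F)(F)c1ccc(CSc2nc(Nc3ccc(Cl)cc3)c3ccccc3n2)cc1` is not yet measured. It differs from compound 2 by 4-chlorophenyl in place of 3-nitrophenyl on a nitrogen on an aromatic ring. Within the data shown here, no measured step covers a chlorine at this ring; the one step that bears on it, a 2.8-fold higher number from compound 1 to compound 2 (0.45 log units; beyond the scatter), only shows that exchanging the substituent on this ring moves this assay by a modest amount. A step of similar size, back towards the level of compound 1, is therefore expected, though a result within the scatter cannot be excluded. Compound 3 is estimated at 15000 nM, with a range of 5000 nM to 45000 nM, the expected step being a 2.1-fold lower number from compound 2 to compound 3 (0.32 log units; beyond the scatter).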

Compound 3, half-maximal inhibitory concentration: 15100 nM
Estimate against measurement, compound 3: 1.0-fold (0.00 log units) below; low and high end bracket the measured number.
By their numbers in this assay, from the lowest: compounds 1 and 3 (each within the scatter of the next); then compound 2.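

In this assay, 4-chlorophenyl in place of 3-nitrophenyl on the nitrogen gives a 2.1-fold lower number from compound 2 to compound 3 (0.32 log units; beyond the scatter), a reversal of about the size of the earlier step, while 4-chlorophenyl in place of 3-(trifluoromethyl)phenyl gives a 1.4-fold higher number from compound 1 to compound 3 (0.13 log units; within the scatter). At this nitrogen, then, two different substituted phenyl groups cannot be told apart, and only the 3-nitrophenyl group of compound 2 stands apart from them. No measurement shown explains this difference between the groups.

Compound 3 differs from compound 1 and compound 2 in both the substituent and the printed ring number, so the contribution of chlorine alone cannot be read from these steps. As far as these compounds go, how an amine or a carboxylic acid on this phenyl ring, or a plain unsubstituted phenyl, would behave remains open.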